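The source may hold more compounds than are shown below. What is called first, only, known or untested is meant among the compounds shown, and "the series" means these compounds.

Measured compounds:
Compound 1, `Cc1n[nH]c(C(=O)O)c1Cc1cccc(-c2cccc(F)c2)c1`, gives 20%.
Compound 2, `Cc1n[nH]c(C(=O)O)c1Cc1cccc(-c2ccccc2F)c1`, gives 5%.
Compound 3, `Cc1n[nH]c(C(=O)O)c1Cc1cccc(-c2ccc(OC(F)(F)F)cc2)c1`, gives 6%.

All three were examined in an assay on isolated protein for inhibition of 2-Hydroxyacid oxidase 2 (Homo sapiens), tested at 1 uM; a higher number here means a stronger effect of the compound at the concentration tested, a lower number a weaker effect. Among these three numbers compound 2 stands lowest; compound 3 sits nearest to it and within the scatter of it, while compound 1 sits furthest above it and beyond the scatter. Among the measured compounds shown here, the only step that can be followed between two compounds that differ in one place is a number 15 percentage points lower from compound 1 to compound 2 (beyond the scatter), a modest drop that comes with 2-fluorophenyl in place of 3-fluorophenyl on an aromatic carbon.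

Compound 4, `Cc1n[nH]c(C(=O)O)c1Cc1cccc(C#N)c1`, has not yet been measured in this assay. It differs from compound 2 as follows: cyano in place of 2-fluorophenyl on an aromatic carbon. For the measured compounds named here, none of the measured steps concerns this kind of change; the one step that exists moves fluorine within an aromatic ring and leaves the ring itself in place, so it gives no direct guide. With compound 2 already low in this assay, and compound 3 within the scatter of it, the expectation for compound 4 is an inhibition near that of compound 2, a step of a number 1 percentage points higher from compound 2 to compound 4 (within the scatter) that is not expected to exceed the scatter. The estimate for compound 4 in this assay is 6%, with a range from -8% to 22%.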

Compound 4, a percentage reported as inhibition, at one concentration (the size of the read-out at that concentration, not a potency): 6%
For compound 4 middle estimate and measured number coincide at the digits printed; low and high end bracket the measured number.
By their numbers in this assay, from the lowest: compounds 2, 3 and 4 (each within the scatter of the next); then compound 1.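

Among the compounds shown here, compound 4 is the first without a phenyl ring on this aromatic carbon, meta to a large group, and in this assay the exchange of 2-fluorophenyl for cyano gives a number 1 percentage points higher from compound 2 to compound 4 (within the scatter), so a group with no ring and far fewer heavy atoms reads the same as the 2-fluorophenyl group. The exchange of 3-fluorophenyl for the same cyano gives a number 14 percentage points lower from compound 1 to compound 4 (beyond the scatter), so at this place the ring with its fluorine in the 3-position can be told apart from cyano, whereas the ring with its fluorine in the 2-position cannot. Nothing available explains either outcome.

With the read-outs of compounds 2, 3 and 4 all low at the single concentration tested, these compounds leave open whether any other small group at this place, such as an amine, a methoxy group or a primary amide, would read differently from cyano. They also leave open whether a second substituent on the 3-fluorophenyl ring, such as a further fluorine or a methyl group, would take the read-out beyond that of compound 1.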